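The source may hold more compounds than are shown below. What is called first, only, known or untested is meant among the compounds shown, and "the series" means these compounds.

Measured in an ADME assay on the whole organism (strain 129/SvEvBrd x C57BL/6) for metabolic stability, with Mus musculus as the target; on this read-out higher numbers stand for a longer-lived compound and lower numbers for a shorter-lived compound:
- compound 1 `CN(C)C(=O)c1nc([C@@H](O)[C@H](O)[C@H](O)CO)c[nH]1`: 4 h
- compound 2 `OC[C@@H](O)[C@@H](O)[C@H](O)c1c[nH]c(-c2cscn2)n1`: 4.2 h

Compound 2, at 4.2 h, sits within the usual scatter of compound 1, so neither can be called longer-lived. The next compound to be measured is compound 3 `OC[C@@H](O)[C@@H](O)[C@H](O)c1c[nH]c(-c2cocn2)n1`, which carries 1,3-oxazol-4-yl in place of 1,3-thiazol-4-yl on an aromatic carbon. The aromatic ring stays five-membered with 2 hetero atoms, and oxygen takes the place of sulfur.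

Going by the values given here, only one measured step bears on this, and it changed the group at the same place: a 1.1-fold higher number from compound 1 to compound 2 (0.02 log units; within the scatter). That swap of dimethylcarbamoyl for 1,3-thiazol-4-yl left the half-life within the scatter, so no step beyond the scatter is expected in this assay. The expected step is no change at the digits printed from compound 2 to compound 3 (within the scatter). The estimate for compound 3 is 4.2 h, with an expected range of 2.2 h to 7.5 h.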

Compound 3, half-life: 1.2 h
Compound 3: the middle estimate sits 3.5-fold (0.54 log units) above what was measured; the whole stated range lies above it.
By their numbers in this assay, from the lowest: compound 3; then compounds 1 and 2 (each within the scatter of the next).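

In this assay this position turns out to be sensitive to what it carries: oxygen in place of sulfur in the five-membered aromatic ring gives a 3.5-fold lower number from compound 2 to compound 3 (0.54 log units; beyond the scatter) even though the heavy-atom and hydrogen-bond counts of the group stay the same. The 1,3-oxazol-4-yl group also compares poorly with dimethylcarbamoyl, with a 3.3-fold lower number from compound 1 to compound 3 (0.52 log units; beyond the scatter) beyond the scatter, whereas 1,3-thiazol-4-yl and dimethylcarbamoyl had stayed within the scatter of each other. No measurement here explains why a single ring atom makes this difference.

The compounds shown leave open whether the shorter half-life follows the ring oxygen itself or the 1,3-oxazol-4-yl group as a whole. They also leave open how a phenyl ring, an amine or a carboxylic acid would fare at this position.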